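The source may report more compounds than this note shows. Statements on the series, on what has been measured and on what is new or still open speak of the compounds shown alone.

In a functional assay on the whole organism for inhibition, with Rattus norvegicus as the target (on this read-out higher numbers stand for an effect only at larger amounts of compound and lower numbers for an effect already at smaller amounts), compound 1 `Cc1ccc2c(c1)c(C1CCN(CCN3CCNC3=O)CC1)cn2-c1ccc(F)cc1` gives 0.0083 umol/kg. Compound 2 `O=C1NCCN1CCN1CCC(c2cn(-c3ccc(F)cc3)c3ccc(Br)cc23)CC1` gives 0.032 umol/kg, the higher of these two exact numbers, so a larger dose is needed for the same effect. Compound 3 `O=C1NCCN1CCN1CC=C(c2cn(-c3ccc(F)cc3)c3ccc(C(F)(F)F)cc23)CC1` gives no exact number, only a limit of > 0.66 umol/kg.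

Compound 4 `O=C1NCCN1CCN1CCC(c2cn(-c3ccc(F)cc3)c3ccc(C(F)(F)F)cc23)CC1` has not yet been measured. Its structure departs from that of compound 2 in one place: trifluoromethyl in place of bromo on an aromatic carbon. In plain terms, trifluoromethyl stands in place of bromo on an aromatic carbon, on a six-membered aromatic ring of carbon only.

The closest measured guide is a swap of one group for another on an aromatic carbon, with bromo in place of methyl. That swap gave a 3.9-fold higher number from compound 1 to compound 2 (0.59 log units; beyond the scatter), a modest change but one beyond the usual scatter. Compound 3 also carries trifluoromethyl, and it offers only (the limit of > 0.66 umol/kg in this assay, at which 1 of the 3 values shown sits). This gives a cautious hint rather than a measured step.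

Resting on a 3.9-fold higher number from compound 1 to compound 2 (0.59 log units; beyond the scatter) and on that limit, a further modest move toward a higher number is expected in this assay. The expected change is a 2.5-fold higher number from compound 2 to compound 4 (0.40 log units; beyond the scatter). For compound 4 the estimate is 0.08 umol/kg, with an expected range from 0.02 umol/kg to 0.4 umol/kg.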

Compound 4, dose for half-maximal effect: 0.11 umol/kg
The estimate for compound 4 lay 1.4-fold (0.14 log units) below the measured number, within the range that was stated.
By their numbers in this assay, from the lowest: compound 1; then compound 2; then compound 4. At a limit, above all of these: compound 3.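

Replacing bromo with trifluoromethyl on this aromatic carbon gives, in this assay, a 3.4-fold higher number from compound 2 to compound 4 (0.54 log units; beyond the scatter), so a larger dose is needed for the same effect. Set against methyl at the same place, the change is a 13-fold higher number from compound 1 to compound 4 (1.12 log units; beyond the scatter), a large step where the earlier pair had shown only a modest one, and the three exact numbers rise in the order methyl, bromo, trifluoromethyl. Trifluoromethyl now has an exact number at this position, while compound 3, the other compound carrying this group, offers only a limit: the limit of > 0.66 umol/kg in this assay, at which 1 of the 4 values shown sits.

The compounds shown hold only methyl, bromo and trifluoromethyl on this carbon, so it remains open how a chlorine atom, a methoxy group, a nitrile or a plain hydrogen would behave there, and whether any group could give a lower number than methyl. Going by these compounds, the steps to compound 3 cannot be read, and so the effect of the one other place where it differs from compound 4 also remains open.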